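Swapping a halogenated phenyl ring on a shared pyridazinone amide

The compounds below may be only part of what the source reports. "The series", "measured", "known", "first", "only" and "open" are said of these compounds alone.

Compound 1 `O=C(Nc1ccc(Oc2ccnc3[nH]ccc23)cc1)c1nn(-c2ccc(Br)cc2F)ccc1=O`: 46400 nM
Compound 2 `O=C(Nc1ccc(Oc2ccnc3[nH]ccc23)cc1)c1nn(-c2ccc(Cl)c(F)c2)ccc1=O`: 5240 nM
Compound 3 `Cn1ccc2c(Oc3ccc(NC(=O)c4nn(-c5ccc(Br)cc5F)ccc4=O)cc3F)ccnc21`: 24000 nM

The three measured compounds were tested in a functional assay on HepG2 cells (Homo sapiens) for cytotoxicity, read by MTT assay, with a stated time of 72 h; a higher number here means a weaker inhibitor, a lower number a stronger inhibitor. Compound 1 and compound 2 share one core and differ only by 4-chloro-3-fluorophenyl in place of 4-bromo-2-fluorophenyl on an aromatic nitrogen; that change gave an 8.9-fold lower number from compound 1 to compound 2 (0.95 log units; beyond the scatter). Compound 3 sits on a different core, and the difference between the two cores is not broken down here. Compound 4 `Cn1ccc2c(Oc3ccc(NC(=O)c4nn(-c5ccc(Cl)c(F)c5)ccc4=O)cc3F)ccnc21` is not yet measured; it differs from compound 3 by 4-chloro-3-fluorophenyl in place of 4-bromo-2-fluorophenyl on an aromatic nitrogen, the same kind of change as that from compound 1 to compound 2, made at the same place. Since compound 3 gives 24000 nM in this assay, and because the earlier step was an 8.9-fold lower number from compound 1 to compound 2 (0.95 log units; beyond the scatter), a step of similar direction is expected, an 8.0-fold lower number from compound 3 to compound 4 (0.90 log units; beyond the scatter), allowing that the same change on a different core need not repeat in full. Compound 4 is therefore estimated at 3000 nM, between 1000 nM and 9000 nM.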

Compound 4, half-maximal inhibitory concentration: 22100 nM
Compound 4: the middle estimate sits 7.4-fold (0.87 log units) below what was measured; measured number outside the range, above it.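

In this assay, putting 4-chloro-3-fluorophenyl in place of 4-bromo-2-fluorophenyl on an aromatic nitrogen gave a 1.1-fold lower number from compound 3 to compound 4 (0.04 log units; within the scatter), so on this core the swap made no measurable difference. The gain seen on the other core therefore did not carry over, and the size of this change depends on the core that carries it: the same change on two cores in this assay, an 8.9-fold lower number (0.95 log units; beyond the scatter) from compound 1 to compound 2 and a 1.1-fold lower number (0.04 log units; within the scatter) from compound 3 to compound 4, 8.2-fold (0.91 log units) apart, beyond the scatter of two such steps

Going by these compounds alone, with only one pair on each core, this does not show which feature of the cores is responsible, or why. From the compounds shown here alone, it remains open whether the larger step would return on a core differing from that of compound 1 in a single place. Also open, going by these compounds, is how a plain phenyl, or a phenyl bearing an amine or a carboxylic acid, would behave on that same nitrogen on either core.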